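This account rests on a few compounds, and the source may have more. Where it says the series, first, only, none or still open, it means among the compounds named here.

Measured so far in a functional assay on COLO 205 cells (Homo sapiens) for cytotoxicity, read by MTT assay, with a stated time of 48 h; a higher number here means a weaker inhibitor, a lower number a stronger inhibitor:
- compound 1 `Fc1cccc(-c2nc(Nc3cccc(Cl)c3)c3cc(F)ccc3n2)c1`: > 50000 nM
- compound 2 `Fc1cccc(-c2nc(Nc3ccccc3Cl)c3cc(F)ccc3n2)c1`: > 50000 nM

Both entries are limits of the assay, not numbers. For compound 1 the value in this assay is a limit, > 50000 nM. For compound 2 the value in this assay is likewise only a limit, > 50000 nM. The step that the two limits leave unreadable from compound 1 to compound 2 is therefore unreadable, since the limit of > 50000 nM in this assay, at which 2 of the 2 values shown sit, covers both values shown. Compound 2 thus stands at that limit with no number of its own.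

Compound 3 `Nc1cccc(Nc2nc(-c3cccc(F)c3)nc3ccc(F)cc23)c1` differs from compound 2 by 3-aminophenyl in place of 2-chlorophenyl on a nitrogen on an aromatic ring. No measured step bears on this change: the single step shown is unreadable, so neither size nor direction can be taken from it, and no movement beyond the scatter is expected from the data at hand. Compound 3 is estimated at 50000 nM in this assay, within 15000 nM to 100000 nM. The step from compound 2 implied by that estimate is a number no higher from compound 2 to compound 3 (the limit leaves the size open), and the most likely outcome is expected to be again a limit rather than a number.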

Compound 3, half-maximal inhibitory concentration: > 50000 nM
Compound 3: no number, only a limit; the forecaster's own chance of this, stated with the estimate: 70%; the middle value sits exactly at the limit.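

In this assay no new step can be read for compound 3 against compound 1 or compound 2, because all three stop at one limit: the limit of > 50000 nM in this assay, at which 3 of the 3 values shown sit.

The compounds shown leave open whether any change on the shared core gives a number rather than a limit in this assay, and how compound 1, compound 2 and compound 3 compare beyond that limit.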